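This account rests on a few compounds, and the source may have more. Where it says the series, first, only, none or still open, it means among the compounds named here.

Compound 1 `COn1c(-c2ccccc2)c(CO)c2cc(C#N)c(C#N)cc21` gives 4990 nM in an assay on isolated protein for inhibition of Amine oxidase [flavin-containing] A (Homo sapiens), read by fluorescence and spectrophotometry, with a stated time of 20 min; on this read-out higher numbers stand for weaker inhibition and lower numbers for stronger inhibition.
Compound 2 `COc1ccc(-c2c(CO)c3cc(C#N)c(C#N)cc3n2OC)cc1` gives 1130 nM in this assay.
Compound 3 `O=C(O)c1cc2cc(-c3ccccc3)n(O)c2cc1C(=O)O` gives 23300 nM in this assay.

Of these three, compound 3 has the highest number in this assay: compounds 1 and 2 both give lower numbers, and the gap to each of them lies beyond the scatter. The only step measured among these compounds, a 4.4-fold lower number from compound 1 to compound 2 (0.65 log units; beyond the scatter), concerns a methoxy in place of hydrogen on an aromatic carbon and leaves the aromatic ring itself untouched.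

Compound 4 `O=C(O)c1cc2cc(-c3cccs3)n(O)c2cc1C(=O)O` differs from compound 3 in one place: thiophen-2-yl in place of phenyl on an aromatic carbon. Going by the values given here, no measured step exchanges one aromatic ring for another, so the methoxy step does not bear on this change, and nothing among the measured compounds shows how such a ring swap affects this assay. With no guidance in either direction, compound 4 is expected to stay close to compound 3, and the step of a 1.2-fold lower number from compound 3 to compound 4 (0.07 log units; within the scatter) is estimated to lie within the scatter. Compound 4 is therefore expected to give 20000 nM in this assay, with a range from 7000 nM to 55000 nM.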

Compound 4, half-maximal inhibitory concentration: > 100000 nM
Compound 4: a limit, no number; the forecaster's own chance of this, stated with the estimate: 10%; middle value at least 5.0-fold (0.69 log units) from the limit.
By their numbers in this assay, from the lowest: compound 2; then compound 1; then compound 3. At a limit, above all of these: compound 4.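

The value of compound 4 is a limit and not a number: the limit of > 100000 nM in this assay, at which 1 of the 4 values shown sits. Thiophen-2-yl in place of phenyl on this aromatic carbon, next to the ring nitrogen, gives an at least 4.2-fold higher number from compound 3 to compound 4 (0.63 log units; beyond the scatter), so in this assay the exchange of one aromatic ring for another at this place is not neutral on the core of compound 3, and it moves the read-out towards weaker inhibition. The earlier compounds shown here showed only what a methoxy group on the aromatic ring does, on a different core, whereas this step shows that the identity of the ring itself matters, even though the five-membered ring brings a sulfur atom and a hydrogen-bond acceptor while the phenyl ring has neither.

As far as these compounds go, because compound 4 sits at a limit, the true size of this step stays open, as does whether the same swap would act alike on the core of compound 1, which carries two nitrile groups and a hydroxymethyl group. The compounds shown also leave open how other rings at this place, such as furan-2-yl or pyridin-2-yl, would behave, and whether a methoxy group on the phenyl ring of compound 3 would help there as well.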